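The source may hold more compounds than are shown below. What is called first, only, known or untested is meant among the compounds shown, and "the series" means these compounds.

Compound 1 `CC(C)=CCc1cc(C(=O)Nc2cc3ccc(OCCCN4CCCCC4)c(C)c3oc2=O)ccc1O` and compound 2 `CC(C)=CCc1cc(C(=O)Nc2cc3ccc(OCCCNCC(N)=O)c(C)c3oc2=O)ccc1O` share one core and differ only in the group on the saturated chain. In a functional assay on SK-BR-3 cells (Homo sapiens) for antiproliferative activity (a lower number here means a stronger inhibitor, a higher number a weaker inhibitor), compound 1 reads > 50000 nM, which is a limit of the assay. Going by the values given here, compound 2 gives 2290 nM, the only actual number so far. Among the compounds with values here, the single measured step is an at least 21-fold lower number from compound 1 to compound 2 (1.33 log units; beyond the scatter).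

Compound 3 `CC(C)=CCc1cc(C(=O)Nc2cc3ccc(OCCCN(C)c4ccccc4)c(C)c3oc2=O)ccc1O` departs from compound 2 at that same place: methyl(phenyl)amino in place of (carbamoylmethyl)amino on a saturated chain carbon, three bonds along the chain from an oxygen on an aromatic ring. Within the data shown here, this removes the (carbamoylmethyl)amino group of compound 2, the group present on the favourable side of an at least 21-fold lower number from compound 1 to compound 2 (1.33 log units; beyond the scatter), so that step is the only guide. Part of that gain is expected to be lost, though one step gives weak support. A moderate move towards a higher number in this assay is therefore expected, estimated as a 3.5-fold higher number from compound 2 to compound 3 (0.54 log units; beyond the scatter). For compound 3 the estimated value is 8000 nM, with an expected range of 1800 nM to 40000 nM.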

Compound 3, half-maximal inhibitory concentration: > 50000 nM
Compound 3 ended at the assay's limit (the forecaster's own chance of this, stated with the estimate: 30%); middle value at least 6.2-fold (0.79 log units) from the limit.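

In this assay compound 3 gives > 50000 nM, which is a limit of the assay. Methyl(phenyl)amino in place of (carbamoylmethyl)amino gives an at least 21-fold higher number from compound 2 to compound 3 (1.33 log units; beyond the scatter), so a second group at this place on the chain fails to keep the activity of compound 2, and among the three compounds shown, only compound 2 gives a readable number. The step between compound 1 and compound 3 cannot be read, and the two cannot be ranked, because both stop at the same boundary: the limit of > 50000 nM in this assay, at which 2 of the 3 values shown sit.

From the compounds shown here alone, it remains open whether the activity of compound 2 depends on the amide end of its side chain or on the hydrogen-bearing amine nitrogen. A simple methylamino group, or a carboxylic acid in place of the primary amide, would help separate these two parts.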